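A few compounds are considered here, and "the series" means these few. Any claim that something is new, unique, unknown or untested is made for them only; others in the source may bear on it.

Of the compounds shown here, three sharing one core have been tested in a functional assay on HCT-116 cells (Homo sapiens) for antiproliferative activity, read by MTT assay, with a stated time of 72 h; a higher number here means a weaker inhibitor, a lower number a stronger inhibitor. Compound 1 `CC(=O)N(C)c1ccc2[nH]c(-c3n[nH]c4ccccc34)cc2n1` gives 14800 nM in this assay, and compound 2 `COc1cccc(C(=O)N(C)c2ccc3[nH]c(-c4n[nH]c5ccccc45)cc3n2)c1` gives 14200 nM; the step of a 1.0-fold lower number from compound 1 to compound 2 (0.02 log units; within the scatter) lies within the scatter. Compound 3 `CN(C(=O)c1ccco1)c1ccc2[nH]c(-c3n[nH]c4ccccc34)cc2n1` gives 30000 nM, the highest of the three numbers, so it is the weakest inhibitor measured so far. Compound 4 `COc1ccc(NC(=O)N(C)c2ccc3[nH]c(-c4n[nH]c5ccccc45)cc3n2)cc1` differs from compound 3 in one place: (4-methoxyphenyl)amino in place of furan-2-yl on a carbonyl carbon. The measured steps that bear on this change are those at the same carbonyl carbon: a 2.0-fold higher number from compound 1 to compound 3 (0.31 log units; beyond the scatter) and a 2.1-fold higher number from compound 2 to compound 3 (0.32 log units; beyond the scatter), both modest, both toward a weaker inhibitor, while the swap of methyl for 3-methoxyphenyl made no difference beyond the scatter. Replacing furan-2-yl with another group is thus expected to undo a modest loss rather than add a new one. On that basis, a step of a 1.7-fold lower number from compound 3 to compound 4 (0.22 log units; within the scatter) is expected in this assay. Compound 4 is estimated at 18000 nM, with a range from 7000 nM to 45000 nM.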

Compound 4, half-maximal inhibitory concentration: 63 nM
The estimate for compound 4 lay 290-fold (2.46 log units) above the measured number, and the stated range ends above it.
By their numbers in this assay, from the lowest: compound 4; then compounds 2 and 1 (each within the scatter of the next); then compound 3.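

At this carbonyl carbon, the choice of group matters far more than methyl, 3-methoxyphenyl and furan-2-yl suggested: those three stayed much closer together in this assay, whereas (4-methoxyphenyl)amino gives a 480-fold lower number from compound 3 to compound 4 (2.68 log units; beyond the scatter). The gain holds against the other two groups as well, with a 230-fold lower number from compound 2 to compound 4 (2.35 log units; beyond the scatter) and a 230-fold lower number from compound 1 to compound 4 (2.37 log units; beyond the scatter), so it does not depend on which earlier group is taken as the reference. No measurement shown here explains why the number falls so far.

The compounds shown leave open whether the gain comes from the amino nitrogen on the carbonyl carbon or from the methoxyphenyl ring it carries. A plain phenylamino group, a methylamino group or a 4-methoxyphenyl group without the amino nitrogen would help separate these parts.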